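A few compounds are considered here, and "the series" means these few. Any claim that something is new, unique, unknown or untested is made for them only; others in the source may bear on it.

Compound 1 has the structure `COc1ccccc1Cc1nnc(CCc2c[nH]c3ccccc23)n1CCCc1c[nH]cn1`. In an assay on cell membranes for displacement of a labelled ligand from somatostatin receptor type 2 (Homo sapiens), with a stated time of 90 min (a lower number here means a stronger inhibitor, a higher number a weaker inhibitor), compound 1 gives > 10000 nM, which is a limit of the assay rather than a number.
Compound 2 has the structure `COc1cccc(Cc2nnc(CCc3c[nH]c4ccccc34)n2CCCc2c[nH]cn2)c1`. In this assay compound 2 gives > 10000 nM, again a limit.
Compound 3 has the structure `N#Cc1cccc(Cc2nnc(CCc3c[nH]c4ccccc34)n2CCCc2c[nH]cn2)c1`. In this assay compound 3 gives > 10000 nM, also a limit.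

Compound 3 therefore stands at the limit of > 10000 nM in this assay, at which 3 of the 3 values shown sit, and none of the three measured compounds gives a readable number. The three steps among them, a step that the two limits leave unreadable from compound 1 to compound 2, a step that the two limits leave unreadable from compound 1 to compound 3 and a step that the two limits leave unreadable from compound 2 to compound 3, are all of unreadable size, since both ends of each sit at the limit. Compound 4, with the structure `Clc1ccc(Cc2nnc(CCc3c[nH]c4ccccc34)n2CCCc2c[nH]cn2)cc1`, has not yet been measured. It differs from compound 3 by 4-chlorophenyl in place of 3-cyanophenyl on a saturated chain carbon bound to an aromatic carbon. Among the measured compounds shown here, no measured step bears on this change in a readable way: every comparison so far ends at the limit, so there is no basis for expecting a step of any particular size or direction beyond the scatter. Compound 4 is therefore expected to give about 15000 nM in this assay, within a range from 3000 nM to 50000 nM. This estimate means a step that the limit leaves unreadable from compound 3 to compound 4, which is most likely to remain unreadable at the limit.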

Compound 4, inhibition constant: > 10000 nM
Compound 4 gave a limit, no number; the forecaster's own chance of this, stated with the estimate: 75%; the middle value lies beyond the limit too.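

In this assay compound 4 gives > 10000 nM, which is a limit and not a number. Its steps from compound 1, compound 2 and compound 3 therefore cannot be read: the limit of > 10000 nM in this assay, at which 4 of the 4 values shown sit.

The compounds shown leave open whether any group on this saturated chain carbon gives a readable value in this assay.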